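This account rests on a few compounds, and the source may have more. Where it says the series, first, only, none or still open, it means among the compounds named here.

Measured so far in an ADME assay on the whole organism (Mus musculus, strain CD1) for pharmacokinetics, read by LC-MS, with a stated time of 24 h, at a dose of 1 mg/kg by the intravenous route; on this read-out lower numbers stand for narrower distribution and higher numbers for wider distribution into tissues 
compound 1 `O=C(O)Cn1nc(Cc2nc3cc(Cl)c(OCC(F)F)cc3[nH]2)c2ccccc2c1=O` gives 33 L/kg 
compound 2 `O=C(O)Cn1nc(Cn2cc3cc(OCC4CC4)c(Cl)cc3n2)c2ccccc2c1=O` gives 69 L/kg 
compound 3 `O=C(O)Cc1nn(Cc2cn3cc(OCC4CC4)c(Cl)cc3n2)c2ccccc2c1=O` gives 18 L/kg 

Compound 3 (18 L/kg) stands within the scatter of compound 1 (33 L/kg), while compound 2 (69 L/kg) gives a higher number, beyond the scatter. Within the data shown here, these compounds differ in more than one place, so no measured pair isolates a single change.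

Compound 4 `C[C@H](C(=O)O)c1nn(Cc2cn3cc(OCC4CC4)c(Cl)cc3n2)c2ccccc2c1=O` differs from compound 3 by one change (methyl in place of hydrogen on a saturated chain carbon bound to an aromatic carbon and a carbonyl carbon), methyl in place of hydrogen on a saturated chain carbon bound to an aromatic carbon and a carbonyl carbon. The same difference reads as carboxymethyl to 1-carboxyethyl. Among the measured compounds shown here, the series holds no measured precedent for this change, so the expectation starts from compound 3 (18 L/kg). No shift beyond the scatter is expected in this assay, and the data favour no clear direction. The expected change is small, with an estimated 1.1-fold lower number from compound 3 to compound 4 (0.05 log units; within the scatter). The estimate for compound 4 is 16 L/kg (expected range 7 L/kg to 36 L/kg).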

Compound 4, volume of distribution at steady state: 17 L/kg
Beside the measured number, compound 4's estimate is 1.1-fold (0.03 log units) below it, and the stated range covers the measured number.
By their numbers in this assay, from the lowest: compounds 4, 3 and 1 (each within the scatter of the next); then compound 2.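

In this assay, among these compounds, methyl in place of hydrogen on a saturated chain carbon bound to an aromatic carbon and a carbonyl carbon gives a 1.1-fold lower number from compound 3 to compound 4 (0.02 log units; within the scatter), the first comparison that isolates one place. At this position, then, the carboxymethyl to 1-carboxyethyl change leaves the volume of distribution indistinguishable from that of compound 3 within the usual scatter of the measurement. No accompanying measurement offers an explanation for this outcome.

One methyl, in one stereochemical form, is a narrow test of this carbon, so the compounds shown leave open whether the opposite configuration, a second methyl or an ethyl group would behave alike. They also leave open how a hydroxyl group on the same carbon would read in this assay, and whether the result carries over to the core of compound 1 or compound 2.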